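The source may report more compounds than this note shows. Statements on the series, on what has been measured and on what is new or still open speak of the compounds shown alone.

Compound 1 `C=CC(=O)Nc1cccc(NC(=O)CSc2nc(Nc3cccc(Cl)c3)c3ccccc3n2)c1` gives 7830 nM in a functional assay on MGC-803 cells (Homo sapiens) for inhibition, read by MTT assay, with a stated time of 72 h; on this read-out lower numbers stand for stronger inhibition and higher numbers for weaker inhibition.
Compound 2 `C=CC(=O)Nc1cccc(NC(=O)CSc2nc(Nc3cccc([N+](=O)[O-])c3)c3ccccc3n2)c1` reaches only a limit in this assay, > 50000 nM.

Compound 2 therefore stands at the weak end of the numbers shown, at the limit of > 50000 nM in this assay, at which 1 of the 2 values shown sits. Compound 3 `C=CC(=O)Nc1cccc(NC(=O)CSc2nc(Nc3cccc(C)c3)c3ccccc3n2)c1` differs from compound 2 by methyl in place of nitro on an aromatic carbon. For the measured compounds named here, the one measured step that touches this position is an at least 6.3-fold higher number from compound 1 to compound 2 (0.80 log units; beyond the scatter), where chloro gave way to nitro and inhibition weakened. Taking nitro away again, now for methyl, is expected to move the number back toward stronger inhibition, with an estimated at least 5.5-fold lower number from compound 2 to compound 3 (0.74 log units; beyond the scatter). Compound 3 is estimated at 9000 nM, within a range from 3000 nM to 40000 nM.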

Compound 3, half-maximal inhibitory concentration: 20900 nM
For compound 3 the middle estimate is 2.3-fold (0.37 log units) below the measured one; the measured number falls inside the stated range.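

Putting methyl in place of nitro gives an at least 2.3-fold lower number from compound 2 to compound 3 (0.37 log units; beyond the scatter) and brings inhibition back to a measured number. Methyl does not match chloro, though: a 2.7-fold higher number from compound 1 to compound 3 (0.43 log units; beyond the scatter) shows that this change away from chloro also weakens inhibition, as nitro did. Compound 2 stands at a limit, so its step is only a bound: the limit of > 50000 nM in this assay, at which 1 of the 3 values shown sits.

The compounds shown leave open what an amine, a carboxylic acid or a methoxy group would do at this position, and whether any group improves on chloro. They also cannot tell why these groups differ.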